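Replacing a Methoxycarbonyl Group with Hydroxycarbamoyl

This account rests on a few compounds, and the source may have more. Where it says the series, first, only, none or still open, it means among the compounds named here.

Measured so far:
compound 1, `COC(=O)c1ccc(OC)c(S(=O)(=O)Nc2ccc3c(c2)cc(C)c(=O)n3C)c1`: 66%
compound 2, `COC(=O)c1ccc(S(=O)(=O)Nc2ccc3c(c2)cc(C)c(=O)n3C)c(OC)c1`: 68%

Of the compounds shown here, two have been tested in a functional assay on HL-60 cells (Homo sapiens) for antiproliferative activity, tested at 100 uM; a lower number here means a weaker effect, a higher number a stronger effect of the compound at the concentration tested. Compound 1 gives 66%, and compound 2, which carries the same groups arranged differently on its outer ring, gives 68%. Compound 1 holds the lower of the two numbers, but the gap to compound 2 lies within the scatter, so the two results are best read as the same level of effect.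

The next compound, compound 3, `COc1ccc(C(=O)NO)cc1S(=O)(=O)Nc1ccc2c(c1)cc(C)c(=O)n2C`, is not yet measured. It differs from compound 1 in one place: hydroxyamino in place of methoxy on a carbonyl carbon. Going by the values given here, nothing among the measured compounds shows what this kind of change does here, since compound 1 and compound 2 share the methoxycarbonyl group. The author therefore expects, with low confidence, a step of moderate size in the upward direction, a number 12 percentage points higher from compound 1 to compound 3 (beyond the scatter). Compound 3 is expected to give about 78%, within a range from 60% to 92%.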

Compound 3, a percentage reported as inhibition, at one concentration (the size of the read-out at that concentration, not a potency): 39%
Beside the measured number, compound 3's estimate is 39 percentage points above it, and the stated range ends above it.
By their numbers in this assay, from the lowest: compound 3; then compounds 1 and 2 (each within the scatter of the next).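

In this assay the change of hydroxyamino in place of methoxy on a carbonyl carbon brings a number 27 percentage points lower from compound 1 to compound 3 (beyond the scatter) and gives the first measured difference in this series, since compound 1 and compound 2 share the methoxycarbonyl group and could show only the same level of effect. At this place, then, the read-out at the single concentration tested does respond to the group on the carbonyl carbon, and in this one pair hydroxycarbamoyl gives the smaller effect, though this is a difference in effect at that concentration and not a measure of potency. Nothing in the data shown accounts for the step.

The compounds shown leave open whether the same change would have a similar effect on the arrangement of groups in compound 2, as this single pair is the only example of the change. They also leave open how the effect would respond to other groups on the carbonyl carbon, such as a carboxylic acid or a simple amine forming a plain amide, which could show whether the step is specific to hydroxyamino or extends to other replacements for methoxy.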